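The source may report more compounds than this note shows. Statements on the series, on what has been measured and on what is new or still open speak of the compounds shown alone.

Of the compounds shown here, two of a shared core have been tested in a functional assay on PC-3 cells (Homo sapiens) for cytotoxicity, read by MTT assay, with a stated time of 72 h; on this read-out higher numbers stand for weaker inhibition and lower numbers for stronger inhibition. Compound 1 `O=[N+]([O-])c1ccc(Nc2nc(SCc3ccc(C(F)(F)F)cc3)nc3ccccc23)cc1` gives 7900 nM. Compound 2 `Cc1ccc(Nc2nc(SCc3ccc(C(F)(F)F)cc3)nc3ccccc23)cc1` gives 21100 nM, which is the higher of the two numbers, so compound 2 is the weaker inhibitor of the pair. Among the measured compounds shown here, the one step measured so far, a 2.7-fold higher number from compound 1 to compound 2 (0.43 log units; beyond the scatter), came with a methyl in place of a nitro group on an aromatic carbon. Compound 3 `COc1ccc(Nc2nc(SCc3ccc(C(F)(F)F)cc3)nc3ccccc23)cc1` differs from compound 2 by methoxy in place of methyl on an aromatic carbon. For the measured compounds named here, no measured step involves a methoxy group, so the only guide is that the sole change seen at this position shifted the number only modestly. For compound 3 the expected step in this assay is a 1.2-fold lower number from compound 2 to compound 3 (0.07 log units; within the scatter), likely not beyond the scatter in either direction. The estimate for compound 3 is therefore 18000 nM, with a range from 7000 nM to 45000 nM.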

Compound 3, half-maximal inhibitory concentration: 16700 nM
For compound 3 the middle estimate is 1.1-fold (0.03 log units) above the measured one, and the stated range covers the measured number.
By their numbers in this assay, from the lowest: compound 1; then compounds 3 and 2 (each within the scatter of the next).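

In this assay, methoxy in place of methyl on this aromatic carbon gives a 1.3-fold lower number from compound 2 to compound 3 (0.10 log units; within the scatter) and so leaves compounds 2 and 3 indistinguishable, even though methoxy adds an oxygen and a hydrogen-bond acceptor that methyl lacks. Methoxy in place of nitro gives a 2.1-fold higher number from compound 1 to compound 3 (0.33 log units; beyond the scatter) and thus repeats, with a second group, the direction seen when methyl replaced nitro, so among these three compounds only the nitro compound, compound 1, stands apart. Nothing at hand explains why the nitro compound differs from the other two.

Among the compounds shown here, whether this gap reflects something particular to nitro remains open, since only three groups have been compared at this position. An amine or a carboxylic acid here could show whether the number can move further in either direction.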